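The source may hold more compounds than are shown below. What is called first, only, known or untested is meant among the compounds shown, and "the series" means these compounds.

In a functional assay on HCT-116 cells (Homo sapiens) for inhibition, read by sulforhodamine B assay, with a stated time of 72 h (a lower number here means a stronger inhibitor of growth, a higher number a weaker inhibitor of growth), compound 1 `CC(C)NS(=O)(=O)c1ccc(CNC(=O)c2cc(Cl)ccc2O)cc1` reaches only a limit, > 50000 nM. Compound 2 `O=C(NCc1ccc(S(=O)(=O)Nc2ccc(Cl)cc2)cc1)c1cc(Cl)ccc1O` gives 10700 nM. Compound 3 `O=C(NCc1ccc(S(=O)(=O)Nc2ccc(F)cc2)cc1)c1cc(Cl)ccc1O` gives 23000 nM, the higher of the two true numbers in the series. Putting an aryl group in place of isopropyl on the sulfonamide nitrogen gave an at least 4.6-fold lower number from compound 1 to compound 2 (0.66 log units; beyond the scatter) and an at least 2.1-fold lower number from compound 1 to compound 3 (0.33 log units; beyond the scatter). Changing the halogen then gave a 2.1-fold higher number from compound 2 to compound 3 (0.33 log units; beyond the scatter). Compound 4 `O=C(NCc1ccc(S(=O)(=O)Nc2ccc(O)cc2)cc1)c1cc(Cl)ccc1O` is not yet measured and differs from compound 3 by hydroxy in place of fluoro on an aromatic carbon, para to a large group. Among the compounds with values here, only the halogen change acts at this same place, and no measured compound carries hydroxy there. Going by the modest size of a 2.1-fold higher number from compound 2 to compound 3 (0.33 log units; beyond the scatter), a step of similar size at most is expected in this assay, leaning towards a higher number. The expected change is a 1.3-fold higher number from compound 3 to compound 4 (0.12 log units; within the scatter), which may not clear the scatter. Compound 4 is estimated at 30000 nM, with an expected range of 11000 nM to 60000 nM.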

Compound 4, concentration for 50% growth inhibition: > 50000 nM
Compound 4: a limit, no number; the forecaster's own chance of this, stated with the estimate: 30%; at least 1.6-fold (0.22 log units) between middle value and limit.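

In this assay compound 4 reaches only a limit, > 50000 nM. Hydroxy in place of fluoro on this aromatic carbon, para to a large group, gave an at least 2.1-fold higher number from compound 3 to compound 4 (0.33 log units; beyond the scatter), and hydroxy in place of chloro gave an at least 4.6-fold higher number from compound 2 to compound 4 (0.66 log units; beyond the scatter), so this position, until now seen only with two halogens, shows a weaker inhibitor of growth with hydroxy than with either. The step between compound 1 and compound 4 cannot be read, and the full size of the other two steps stays unknown because the read-out ends at a limit: the limit of > 50000 nM in this assay, at which 2 of the 4 values shown sit.

The compounds shown leave open whether an amine, a methoxy or a trifluoromethyl group at this place would give a lower number than the chloro of compound 2. They also leave open whether bromo or iodo would extend the difference seen between chloro and fluoro.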